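The source may report more compounds than this note shows. Statements on the series, on what has been measured and on what is new or still open speak of the compounds shown alone.

Three compounds of the shared core have been run in an ADME assay on MT4 cells (Homo sapiens) for cytotoxicity, read by MTT assay, with a stated time of 4 days; a higher number here means that more compound is tolerated, a lower number that less compound is tolerated. Compound 1 `Cc1ccccc1-c1cc(C)c(Nc2ccnc(Nc3ccc(C#N)cc3)n2)c(C)c1` gives 3820 nM, compound 2 `Cc1cccc(-c2cc(C)c(Nc3ccnc(Nc4ccc(C#N)cc4)n3)c(C)c2)c1` gives 3670 nM, and compound 3 `Cc1cc(-c2cccc(Cl)c2)cc(C)c1Nc1ccnc(Nc2ccc(C#N)cc2)n1` gives 2160 nM. Compound 2 sits among these with both neighbours: the step of a 1.0-fold lower number from compound 1 to compound 2 (0.02 log units; within the scatter) and the step of a 1.7-fold lower number from compound 2 to compound 3 (0.23 log units; within the scatter) both lie within the scatter, as does a 1.8-fold lower number from compound 1 to compound 3 (0.25 log units; within the scatter).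

Compound 4 `Cc1cc(-c2cc(F)cc(F)c2)cc(C)c1Nc1ccnc(Nc2ccc(C#N)cc2)n1` is not yet measured in this assay. Against compound 2 the change is 3,5-difluorophenyl in place of 3-methylphenyl on an aromatic carbon.

Among the measured compounds shown here, two measured steps bear on this. Moving the methyl from one position of the phenyl to another, a 1.0-fold lower number from compound 1 to compound 2 (0.02 log units; within the scatter), changed nothing beyond the scatter. Exchanging methyl for chloro on that ring, a 1.7-fold lower number from compound 2 to compound 3 (0.23 log units; within the scatter), also stayed within the scatter. Halogen for methyl on the pendant phenyl has therefore not moved this assay so far, and no step beyond the scatter is expected for compound 4 either, at most a drift toward the chloro case.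

Compound 4 is expected at 2900 nM, with a range of 1400 nM to 6000 nM, which means an expected step of a 1.3-fold lower number from compound 2 to compound 4 (0.10 log units; within the scatter).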

Compound 4, half-maximal cytotoxic concentration: 3910 nM
The estimate for compound 4 lay 1.3-fold (0.13 log units) below the measured number; the range from low to high includes it.
By their numbers in this assay, from the lowest: compounds 3, 2, 1 and 4 (each within the scatter of the next).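

Replacing 3-methylphenyl with 3,5-difluorophenyl in this assay gives a 1.1-fold higher number from compound 2 to compound 4 (0.03 log units; within the scatter) and so shows that two fluorines on the pendant ring can be carried at this position without a step beyond the scatter. The same holds against the other aryl groups, with a 1.0-fold higher number from compound 1 to compound 4 (0.01 log units; within the scatter) and a 1.8-fold higher number from compound 3 to compound 4 (0.26 log units; within the scatter) both printed as within the scatter. Across the four compounds, 2-methylphenyl, 3-methylphenyl, 3-chlorophenyl and 3,5-difluorophenyl therefore cannot be told apart in this read-out, and no measurement here offers an explanation for that.

All four groups are phenyl rings bearing methyl, chloro or fluoro. On these data alone, whether an amine, a carboxylic acid or a longer chain at this position would give a step beyond the scatter remains open.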